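Triazole-bearing lactone series: removing the aryl sulfonamide arm

The source may report more compounds than this note shows. Statements on the series, on what has been measured and on what is new or still open speak of the compounds shown alone.

Measured compounds:
compound 1 `O=C1O[C@H]([C@@H](O)Cn2cc(-c3cc(F)cc(F)c3)nn2)C(OCc2ccccc2)=C1OCc1ccccc1` – 41200 nM
compound 2 `CCCCCc1ccc(-c2cn(C[C@H](O)[C@H]3OC(=O)C(OCc4ccccc4)=C3OCc3ccccc3)nn2)cc1` – 6220 nM
compound 3 `O=C1O[C@H]([C@@H](O)Cn2cc(CNS(=O)(=O)c3ccc(Cl)cc3)nn2)C(OCc2ccccc2)=C1OCc1ccccc1` – 2870 nM

All three share the same core and differ only in the group on one aromatic carbon of the triazole. In a functional assay on A549 cells (Homo sapiens) for antiproliferative activity, read by MTT assay, with a stated time of 72 h (on this read-out lower numbers stand for stronger inhibition and higher numbers for weaker inhibition), compound 3 stands lowest of the three numbers: the step of a 14-fold lower number from compound 1 to compound 3 (1.16 log units; beyond the scatter) is large, and the step of a 2.2-fold lower number from compound 2 to compound 3 (0.34 log units; beyond the scatter) is modest, so compound 3 is separated from both others beyond the scatter. The step of a 6.6-fold lower number from compound 1 to compound 2 (0.82 log units; beyond the scatter) is also beyond the scatter.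

Compound 4 `O=C1O[C@H]([C@@H](O)Cn2ccnn2)C(OCc2ccccc2)=C1OCc1ccccc1` carries nothing at that position: hydrogen in place of (((4-chlorophenyl)sulfonyl)amino)methyl on an aromatic carbon. Going by the values given here, no measured compound has hydrogen there, so the step from compound 3 to compound 4 is not directly precedented. The two steps that bear on it, the large 14-fold lower number from compound 1 to compound 3 (1.16 log units; beyond the scatter) and the modest 2.2-fold lower number from compound 2 to compound 3 (0.34 log units; beyond the scatter), both show the (((4-chlorophenyl)sulfonyl)amino)methyl group going with the lowest number in the set, and every substituent so far has given a number no higher than that of compound 1. Taking the group away entirely is therefore expected to move the number upward, plausibly to the weaker end of the range seen.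

For compound 4 the estimate is 20000 nM, with a range from 5000 nM to 70000 nM, meaning an expected step of a 7.0-fold higher number from compound 3 to compound 4 (0.84 log units; beyond the scatter).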

Compound 4, half-maximal inhibitory concentration: > 100000 nM
Compound 4: no number, only a limit (the forecaster's own chance of this, stated with the estimate: 10%); middle value at least 5.0-fold (0.69 log units) away from the limit.
By their numbers in this assay, from the lowest: compound 3; then compound 2; then compound 1. At a limit, above all of these: compound 4.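

In this assay, compound 4 is recorded only as a limit of the assay, not as a number: the limit of > 100000 nM in this assay, at which 1 of the 4 values shown sits. Read against this limit, each substituent on this aromatic carbon of the triazole goes with a lower number than hydrogen does, with an at least 34-fold higher number from compound 3 to compound 4 (1.54 log units; beyond the scatter), an at least 16-fold higher number from compound 2 to compound 4 (1.20 log units; beyond the scatter) and an at least 2.4-fold higher number from compound 1 to compound 4 (0.38 log units; beyond the scatter), all beyond the scatter. The earlier compounds shown here only ranked three substituents against one another, whereas these steps show that the shared core with hydrogen at this position falls outside the measured range and that even 3,5-difluorophenyl, with the smallest of the three steps, goes with a measurable number.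

On these data alone, the limit fixes only the smallest possible size of each step, so the true distance from hydrogen to each substituent stays open. Also open, as far as these compounds go, is which part of (((4-chlorophenyl)sulfonyl)amino)methyl goes with the lowest number, and whether a simple aminomethyl, a carboxylic acid or a plain pentyl chain on this carbon would give a number within the range of compound 1, compound 2 and compound 3.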